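The compounds below may be only part of what the source reports. "The series", "measured", "known", "first", "only" and "open" are said of these compounds alone.

Compound 1, `O=C(Nc1cccc(Cl)c1)c1ccccc1O`: in an assay for inhibition of HSP60/HSP10 (Homo sapiens), with a stated time of 60 min (a lower number here means a stronger inhibitor, a higher number a weaker inhibitor), compound 1 gives > 100000 nM, which is a limit of the assay and not a number.
Compound 2, `O=C(Nc1ccc(Sc2nc3ccccc3s2)c(Cl)c1)c1cc(Br)cc(Br)c1`: in this assay compound 2 gives > 100000 nM, again a limit.
Compound 3, `O=C(Nc1ccc(Sc2nc3ccccc3s2)cc1)c1cc(Br)cc(Br)c1`: in this assay compound 3 gives > 100000 nM, also a limit.

Compound 3 therefore stands nowhere on a scale: only a limit is known for it, and the two other values shown are limits as well, so that no order among the three compounds can be read. Within the data shown here, the single measured step, a step that the two limits leave unreadable from compound 2 to compound 3, is unreadable for the same reason.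

Compound 4, `O=C(Nc1ccc(Sc2nc3ccccc3s2)cc1)c1cc(Br)cc(Br)c1O`, arises from compound 3 by hydroxy in place of hydrogen on an aromatic carbon. Among the measured compounds shown here, no measured step bears on this change; compound 1, which also carries a hydroxy group, is itself no more than a limit. The only evidence is the limit of > 100000 nM in this assay, at which 3 of the 3 values shown sit, and nothing in the shown compounds points away from it.

For this assay the step from compound 3 to compound 4 is therefore expected to be none readable, a number no higher from compound 3 to compound 4 (the limit leaves the size open). Compound 4 is accordingly expected to give about 100000 nM, with a range from 30000 nM to 300000 nM, most likely reported as a limit again.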

Compound 4, half-maximal inhibitory concentration: 4700 nM
Estimate against measurement, compound 4: 21-fold (1.33 log units) above; measured number below the stated range.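

Set on the 3,5-dibromophenyl group, ortho to a bromo group and para to a bromo group, hydroxy in place of hydrogen on an aromatic carbon gives in this assay an at least 21-fold lower number from compound 3 to compound 4 (1.32 log units; beyond the scatter). Among these compounds, this is the first step that can be read: the step between compound 2 and compound 3 cannot, as both ends of it are limits, so the earlier compounds showed no change that moved the number at all. Compound 4 is also the only compound shown that has a measured number and not a limit of the assay: the limit of > 100000 nM in this assay, at which 3 of the 4 values shown sit.

Because compound 3 is only a limit, the true size of the step stays open, and the compounds shown do not tell whether a methoxy group, an amine or a carboxylic acid at this same position would serve as the hydroxy group does, or whether hydroxy would have the same result at another position of the ring. They also leave open what the chloro group of compound 2 would do to the number once the hydroxy group is present.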